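The compounds below may be only part of what the source reports. "The series", "measured", "known", "first", "only" and "open" are said of these compounds alone.

Three compounds share one core. Compound 1 `Cc1cc(S(=O)(=O)Nc2nc3ccsc3c(=O)n2Cc2ccccc2)c(S)cc1Cl` carries a hydrogen on the aromatic carbon in question, compound 2 `Cc1cc(S(=O)(=O)Nc2nc3cc(-c4ccccc4)sc3c(=O)n2Cc2ccccc2)c(S)cc1Cl` carries a phenyl there, and compound 3 `Cc1cc(S(=O)(=O)Nc2nc3cc(-c4ccc(Cl)cc4)sc3c(=O)n2Cc2ccccc2)c(S)cc1Cl` carries a 4-chlorophenyl there and has not yet been measured. In a functional assay on Malme-3M cells (Homo sapiens) for inhibition (a higher number here means a weaker inhibitor of growth, a lower number a stronger inhibitor of growth), compound 1 gives 19900 nM. Compound 2 reaches only the limit of this assay, giving > 100000 nM. Phenyl in place of hydrogen on an aromatic carbon therefore produced an at least 5.0-fold higher number from compound 1 to compound 2 (0.70 log units; beyond the scatter), a step whose size is only a bound that rests on (the limit of > 100000 nM in this assay, at which 1 of the 2 values shown sits). Compound 2 thus stands at the weak end of the two measured values, at the limit itself. Compound 3 differs from compound 2 by chloro in place of hydrogen on an aromatic carbon. Among the compounds with values here, only one measured step bears on this change, the one from compound 1 to compound 2, and it points toward weaker inhibition; no measured step touches a substituent on the added phenyl. Compound 2 already sits at the limit of this assay. Compound 3 is accordingly expected to give a number at or past that limit, with a step that the limit leaves unreadable from compound 2 to compound 3 expected to be small. The estimate for compound 3 is 150000 nM, with a range from 50000 nM to 500000 nM.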

Compound 3, concentration for 50% growth inhibition: > 100000 nM
Compound 3 ended at the assay's limit; the forecaster's own chance of this, stated with the estimate: 85%; the middle value is on the limit's open side.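

With 4-chlorophenyl in place of hydrogen on this aromatic carbon, this assay shows an at least 5.0-fold higher number from compound 1 to compound 3 (0.70 log units; beyond the scatter), so the loss seen with phenyl now holds for a second aryl group, and neither compound carrying such a group goes against it. Compound 3 gives > 100000 nM, which is a limit of the assay and not a number. The chloro on the phenyl therefore shows no recovery of growth inhibition in this assay, but any difference between phenyl and 4-chlorophenyl cannot be read, because both compounds stand at the same limit: the limit of > 100000 nM in this assay, at which 2 of the 3 values shown sit.

As far as these compounds go, how far compound 2 and compound 3 lie past that limit remains open, and so does whether the chloro makes any difference at all. Also open, from the compounds shown here alone, is whether a methyl or a methoxy on this aromatic carbon would keep the value of compound 1, or whether an amine or a carboxylic acid on the phenyl would bring the number back within the range of this assay.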